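A few compounds are considered here, and "the series" means these few. Any claim that something is new, unique, unknown or untested is made for them only; others in the source may bear on it.

Measured compounds:
compound 1, `Cc1cccc(/C(N)=N/NC(=S)N2CCCCC2)n1`, 63.2%
compound 2, `Cc1cccc(/C(N)=N/NC(=S)N2CCCC2)n1`, 51.3%
compound 3, `Cc1ccnc(/C(N)=N/NC(=S)N2CCOCC2)c1`, 66.6%

The account follows compound 1 in a functional assay on A-375 cells (Homo sapiens) for cytotoxicity, read by MTT assay, with a stated time of 72 h, tested at 3 uM; a lower number here means less inhibition of growth, a higher number more inhibition of growth at the concentration tested. Among the three measured values, compound 1 stands second highest; its nearest neighbour is compound 3, whose value lies within the scatter of that of compound 1, and its furthest is compound 2. Among the measured compounds shown here, the only step that joins two measured compounds differing in a single place is a number 11.9 percentage points lower from compound 1 to compound 2 (beyond the scatter), which concerns the ring on the thiocarbonyl carbon and says nothing about the aromatic ring. The unmeasured compound 4, `N/C(=N\NC(=S)N1CCCCC1)c1ccccn1`, differs from compound 1 by hydrogen in place of methyl on an aromatic carbon. For the measured compounds named here, no measured pair isolates this change, so the expectation rests only on the spread of the three values, all of which sit within a modest band. The loss of a single carbon from the aromatic ring is therefore expected to leave the value close to that of compound 1, with no step beyond the scatter anticipated: the estimated step is a number 3.2 percentage points lower from compound 1 to compound 4 (within the scatter). Compound 4 is estimated at 60%, with a range from 45% to 75%.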

Compound 4, percent growth inhibition at one concentration: 86.5%
Compound 4: the middle estimate sits 26.5 percentage points below what was measured; the measured number lies above the stated range.
By their numbers in this assay, from the lowest: compound 2; then compounds 1 and 3 (each within the scatter of the next); then compound 4.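

In this assay, among the compounds shown here, hydrogen in place of methyl on the aromatic carbon next to the ring nitrogen gives a number 23.3 percentage points higher from compound 1 to compound 4 (beyond the scatter) and so shows that this position of the shared core, which no earlier pair had isolated, responds strongly to a small change. For the compounds shown here, the only earlier single-place step, a number 11.9 percentage points lower from compound 1 to compound 2 (beyond the scatter) at the ring on the thiocarbonyl carbon, ran downward, whereas this one runs upward and is the larger of the two, although only one carbon leaves and no hydrogen-bond donor, acceptor or charge is lost. No measurement at hand explains why the methyl has this effect.

The compounds shown leave open whether the gain belongs to hydrogen itself or whether a methoxy group, a chlorine atom or an amine on that aromatic carbon would also lift the number above that of compound 1. They also leave open whether the same change would carry over to the analogue with pyrrolidin-1-yl on the thiocarbonyl carbon, where the methyl-bearing compound 2 stands lowest of the series.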